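Chain trimming on compound 1: cytotoxicity notes

The compounds below may be only part of what the source reports. "The series", "measured", "known", "first", "only" and "open" are said of these compounds alone.

Values in a functional assay on HEL cells (Homo sapiens) (a lower number here means that less compound is tolerated, a higher number that more compound is tolerated), so far
compound 1 `CCCCCCCCCCCc1cc2cn(COCCO)c(=O)nc2o1` gives 132000 nM in this series
compound 2 `CCCCCCCCC#Cc1cc2cn(COCCO)c(=O)nc2o1` gives 42000 nM in this series
compound 3 `OCCOCn1cc2ccnc-2nc1O` gives > 200000 nM as a limit, not a number

Compound 1 has the higher of the two true numbers, and compound 2 lies lower by a gap beyond the scatter. Compound 3 has only a limit and cannot be ranked against them.

Compound 4 `CCCCCCCCc1cc2cn(COCCO)c(=O)nc2o1` departs from compound 1 by hydrogen in place of propyl on a saturated chain carbon, eight bonds along the chain from an aromatic carbon and so has hydrogen in place of propyl on a saturated chain carbon, eight bonds along the chain from an aromatic carbon. Among the compounds with values here, no measured pair isolates this change, so the expectation is loose. Compound 3, which has no long chain, gives > 200000 nM as a limit. A small upward move that stays within the scatter is expected, as a 1.1-fold higher number from compound 1 to compound 4 (0.06 log units; within the scatter) in this estimate. In this assay the estimate for compound 4 is 150000 nM with 70000 nM to 200000 nM as its expected range.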

Compound 4, half-maximal cytotoxic concentration: > 200000 nM
Compound 4: only a limit was reported; the forecaster's own chance of this, stated with the estimate: 35%; at least 1.3-fold (0.12 log units) between middle value and limit.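

In this assay, hydrogen in place of propyl on a saturated chain carbon, eight bonds along the chain from an aromatic carbon, gives an at least 1.5-fold higher number from compound 1 to compound 4 (0.18 log units; that floor lies within the scatter). Compound 4 gives > 200000 nM, which is a limit and not a number, so this change has a floor but no measured size, and that floor alone does not separate it from the scatter. This is the first pair in the series to isolate a change in the saturated chain, and its reading stops at a ceiling: the limit of > 200000 nM in this assay, at which 2 of the 4 values shown sit.

From the compounds shown here alone, how far the true value of compound 4 lies past that limit stays open. Also open, going by these compounds, is how a longer chain, or an amine or a carboxylic acid at the end of the chain, would read in this assay.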